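The source may hold more compounds than are shown below. What is called first, only, known or untested is meant among the compounds shown, and "the series" means these compounds.

Compound 1 `C[C@H]1O[C@@H](n2cnc3c(N)nc(I)nc32)[C@H](O)[C@@H]1O` gives 110000 nM in an ADME assay on L6 cells (Rattus norvegicus) for cytotoxicity; a higher number here means a weaker inhibitor, a lower number a stronger inhibitor. Compound 2 `CS[C@H]1O[C@@H](n2cnc3c(N)nc(I)nc32)[C@H](O)[C@@H]1O` carries the change (methylsulfanyl in place of methyl on a saturated ring carbon); in this assay compound 2 gives 137000 nM, a step of a 1.2-fold higher number from compound 1 to compound 2 (0.10 log units; within the scatter). Compound 3 `CNc1nc(I)nc2c1ncn2[C@@H]1O[C@H](C)[C@@H](O)[C@H]1O` differs from compound 1 by methyl in place of hydrogen on a nitrogen on an aromatic ring; in this assay compound 3 gives 137000 nM, a step of a 1.2-fold higher number from compound 1 to compound 3 (0.10 log units; within the scatter). Compound 4 `CNc1nc(I)nc2c1ncn2[C@@H]1O[C@H](SC)[C@@H](O)[C@H]1O` is not yet measured; it relates to compound 3 by methylsulfanyl in place of methyl on a saturated ring carbon, the same change as that made from compound 1 to compound 2, here on the core of compound 3. For compound 4 the expected step is a 1.2-fold higher number from compound 3 to compound 4 (0.07 log units; within the scatter), resting on the earlier measured step of a 1.2-fold higher number from compound 1 to compound 2 (0.10 log units; within the scatter), which stayed within the scatter. Compound 4 is estimated at 160000 nM in this assay, expected to fall between 95000 nM and 270000 nM.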

Compound 4, half-maximal inhibitory concentration: 120000 nM
The estimate for compound 4 lay 1.3-fold (0.12 log units) above the measured number; the measured number falls inside the stated range.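

In this assay, methylsulfanyl in place of methyl on a saturated ring carbon gives a 1.1-fold lower number from compound 3 to compound 4 (0.06 log units; within the scatter), and this step does not differ from its earlier counterpart beyond the scatter: the same change on two cores in this assay, a 1.2-fold higher number (0.10 log units; within the scatter) from compound 1 to compound 2 and a 1.1-fold lower number (0.06 log units; within the scatter) from compound 3 to compound 4, 1.4-fold (0.15 log units) apart, within the scatter of two such steps
Methyl in place of hydrogen on a nitrogen on an aromatic ring gives a 1.1-fold lower number from compound 2 to compound 4 (0.06 log units; within the scatter), and the same holds for this change: the same change on two cores in this assay, a 1.2-fold higher number (0.10 log units; within the scatter) from compound 1 to compound 3 and a 1.1-fold lower number (0.06 log units; within the scatter) from compound 2 to compound 4, 1.4-fold (0.15 log units) apart, within the scatter of two such steps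
Both changes therefore stay within the scatter on both cores, which shows agreement only among small steps and does not show that a step beyond the scatter would carry from one core to another.

The compounds shown leave open whether an amine or a carboxylic acid in place of methylsulfanyl would move the number beyond the scatter. The same question stands for a longer chain in place of methyl on that nitrogen.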